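Furan replacement at the chain amine in the phenoxy series

The compounds below may be only part of what the source reports. "The series", "measured", "known", "first", "only" and "open" are said of these compounds alone.

Compound 2 `Clc1ccc(Oc2ccc3c(NCCCNCc4ccco4)ccnc3c2)cc1` gives 317 10^-6 cm/s in an ADME assay for permeability, using PAMPA, with a stated time of 30 min, at pH 7.4 (on this read-out lower numbers stand for lower permeability and higher numbers for higher permeability), the higher of two numbers; compound 1 `COc1ccc(-c2ccc3c(NCCCNCc4ccco4)ccnc3c2)cc1` gives 237 10^-6 cm/s in this assay, and the two sit within the scatter (a 1.3-fold higher number from compound 1 to compound 2 (0.13 log units; within the scatter)). Compound 3 `COc1cccc(CNCCCNc2ccnc3cc(Oc4ccc(Cl)cc4)ccc23)c1O` differs from compound 2 as follows: 2-hydroxy-3-methoxyphenyl in place of furan-2-yl on a saturated chain carbon bound to an amine nitrogen. Among the measured compounds shown here, the one measured step concerns the aryl substituent on the core, not the chain amine, so no measured step bears on this change; with one donor entering, a modest fall is expected. For compound 3 the estimate is 150 10^-6 cm/s, range 60 10^-6 cm/s to 320 10^-6 cm/s, a step of a 2.1-fold lower number from compound 2 to compound 3 (0.32 log units; beyond the scatter).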

Compound 3, apparent permeability: 317 10^-6 cm/s
Compound 3: middle estimate off by 2.1-fold (0.32 log units), on the low side, and the stated range covers the measured number.
By their numbers in this assay, from the lowest: compounds 1, 2 and 3 (each within the scatter of the next).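

Among the compounds shown here, at the saturated chain carbon bound to an amine nitrogen, the first measured step in this assay is no change at the digits printed from compound 2 to compound 3 (within the scatter). A larger group, 2-hydroxy-3-methoxyphenyl with its hydrogen-bond donor, thus stands in place of furan-2-yl with the number still within the scatter of compound 2. No data here bear on the reason for this result.

From the compounds shown here alone, whether the hydroxy and methoxy groups each matter alone remains open, since compound 3 carries both. Also open, going by these compounds, is how a plain benzyl group or a carboxylic acid would read at this place.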